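Cyclopentyl in Place of Trifluoromethoxyphenyl on the Ring Amine

This account rests on a few compounds, and the source may have more. Where it says the series, first, only, none or still open, it means among the compounds named here.

Measured compounds:
compound 1 `Nc1scc(CN2CCN(c3ccc(Cl)cc3Cl)CC2)c1C(=O)c1ccc(Cl)cc1`: 0%
compound 2 `Nc1scc(CN2CCN(c3ccc(Cl)c(C(F)(F)F)c3)CC2)c1C(=O)c1ccc(Cl)cc1`: 3%
compound 3 `Nc1scc(CN2CCN(c3ccc(OC(F)(F)F)cc3)CC2)c1C(=O)c1ccc(Cl)cc1`: 1%

In an assay on CHO cells for displacement of a labelled ligand from adenosine receptor A3 (Homo sapiens), read by scintillation counting, with a stated time of 120 min, tested at 10 uM (a higher number here means more inhibition at the concentration tested (going by the name of the read-out), a lower number less inhibition), all three measured compounds share one core and differ only in the aromatic group on an amine nitrogen in a ring. Compound 3 holds the second highest of the three numbers; its nearest neighbour is compound 1, with a number 1 percentage points higher from compound 1 to compound 3 (within the scatter), and its furthest is compound 2, with a number 2 percentage points lower from compound 2 to compound 3 (within the scatter). The remaining pair shows a number 3 percentage points higher from compound 1 to compound 2 (within the scatter).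

Compound 4 `Nc1scc(CN2CCN(C3CCCC3)CC2)c1C(=O)c1ccc(Cl)cc1` has not been measured. It differs from compound 3 in one place: cyclopentyl in place of 4-(trifluoromethoxy)phenyl on an amine nitrogen in a ring. Every measured step exchanges one aromatic group for another at this position and stays within the scatter; none replaces an aromatic ring with a non-aromatic one, so the closest guide is the flat response seen so far. Compound 4 is therefore expected to show a number 1 percentage points higher from compound 3 to compound 4 (within the scatter), no step beyond the scatter. The estimate for compound 4 in this assay is 2%, within -8% to 12%.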

Compound 4, a percentage reported as inhibition, at one concentration (the size of the read-out at that concentration, not a potency): 3%
Beside the measured number, compound 4's estimate is 1 percentage points below it, within the range that was stated.
By their numbers in this assay, from the lowest: compounds 1, 3, 2 and 4 (each within the scatter of the next).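

In this assay, replacing an aromatic group on this amine nitrogen with a non-aromatic ring moves nothing beyond the scatter: cyclopentyl gives a number 2 percentage points higher from compound 3 to compound 4 (within the scatter) and no change at the digits printed from compound 2 to compound 4 (within the scatter) and also a number 3 percentage points higher from compound 1 to compound 4 (within the scatter) within the same flat band. The flat response at this position therefore now covers a smaller carbon-only ring as well as the aromatic groups. Nothing available explains this flatness. Going by these compounds, whether a carboxylic acid or a longer chain bearing an amine at this nitrogen would lift the number remains open. So does the effect of any change elsewhere on the shared core.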